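This account rests on a few compounds, and the source may have more. Where it says the series, first, only, none or still open, it means among the compounds named here.

Measured so far in an ADME assay on Vero cells (Chlorocebus sabaeus) for cytotoxicity, read by CCK-8 assay, with a stated time of 72 h; a higher number here means a weaker inhibitor, a lower number a stronger inhibitor:

Compound 1 `Cc1ccn2nc(C)c(C(=O)NCc3ccc(N(C)C)cc3)c2c1` — in this assay compound 1 gives > 100000 nM, which is a limit of the assay and not a number.
Compound 2 `Cc1ccn2nc(C)c(C(=O)NCc3ccc(-c4ccc(OC(F)(F)F)cc4)cc3)c2c1` — in this assay compound 2 gives 50700 nM.
Compound 3 `Cc1ccn2nc(C)c(C(=O)NCc3ccc(N4CCC(c5ccc(OC(F)(F)F)cc5)CC4)cc3)c2c1` — in this assay compound 3 gives > 100000 nM, which is a limit of the assay and not a number.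

Compound 3 stands at the limit of > 100000 nM in this assay, at which 2 of the 3 values shown sit; for compound 3 only this limit is known, no number. For the measured compounds named here, compound 2 is the one compound of the three with a number in this assay. Going by the values given here, no pair of measured compounds differs in a single place, so no measured step is available to rest on.

Compound 4 `CCc1ccn2nc(C)c(C(=O)NCc3ccc(N4CCC(c5ccc(OC(F)(F)F)cc5)CC4)cc3)c2c1` differs from compound 3 by methyl in place of hydrogen on a saturated chain carbon bound to an aromatic carbon; cut one bond further out, the same change reads methyl to ethyl. Among the compounds with values here, with no measured step to draw on, no step beyond the scatter in this assay is expected in either direction. Compound 4 is expected to sit at 100000 nM, within 50000 nM to 200000 nM, and most likely to be reported again only as a limit. The step of a number no higher from compound 3 to compound 4 (the limit leaves the size open) that this estimate means is expected to stay within the scatter.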

Compound 4, half-maximal inhibitory concentration: > 100000 nM
Compound 4 ended at the assay's limit; the forecaster's own chance of this, stated with the estimate: 70%; the middle value sits exactly at the limit.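

Compound 3 and compound 4 both stand only as limits of the assay in this assay, so no step between them can be read: the limit of > 100000 nM in this assay, at which 3 of the 4 values shown sit.

The compounds shown leave open whether methyl in place of hydrogen on a saturated chain carbon bound to an aromatic carbon changes the value at all.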